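This account rests on a few compounds, and the source may have more. Where it says the series, first, only, none or still open, it means among the compounds named here.

Compound 1, `CN(Cc1ccccc1)/N=N/c1ccccc1`: > 100000 nM
Compound 2, `Fc1ccc(F)c(/N=N/Nc2ccccc2)c1`: > 100000 nM

Both compounds were examined in an ADME assay on BHK-21 cells (Mesocricetus auratus) for cytotoxicity, read by MTT assay, with a stated time of 96 h; on this read-out higher numbers stand for lower toxicity in this test and lower numbers for higher toxicity in this test. In this assay compound 1 gives > 100000 nM, which is a limit of the assay rather than a number. Compound 2 likewise reaches only a limit, with > 100000 nM. Compound 1 therefore stands at the edge of what the assay resolves, and so does its only companion: the limit of > 100000 nM in this assay, at which 2 of the 2 values shown sit. No ordering between the two can be read from this.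

Compound 3, `c1ccc(CN/N=N/c2ccccc2)cc1`, has not yet been measured. It differs from compound 1 in one place: hydrogen in place of methyl on an amine nitrogen. Going by the values given here, no step between two measured compounds is available that would show how such a change moves the read-out, and the two values that exist both rest at the limit. The expected step in this assay is a number no higher from compound 1 to compound 3 (the limit leaves the size open), none beyond the usual scatter. Compound 3 is estimated at 100000 nM, with a range from 50000 nM to 200000 nM, and most likely it will again be reported only as a limit.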

Compound 3, half-maximal cytotoxic concentration: > 100000 nM
Compound 3: only a limit was reported (the forecaster's own chance of this, stated with the estimate: 85%); the middle value sits exactly at the limit.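

No new step can be read from compound 1 to compound 3, since each is reported only as a limit, so the effect of hydrogen in place of methyl stays unreadable: the limit of > 100000 nM in this assay, at which 3 of the 3 values shown sit.

The compounds shown leave open how any of them would rank, and what effect this change would have, on a value that this assay can resolve.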